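Fluoro for Methoxy Across Two Cores

The source may report more compounds than this note shows. Statements on the series, on what has been measured and on what is new or still open speak of the compounds shown alone.

Measured compounds:
compound 1, `C=C(c1ccc(F)c(F)c1)C1COC(C)(C)OO1`, > 100000 nM
compound 2, `C=C(c1ccc(OC)c(F)c1)C1COC(C)(C)OO1`, 68700 nM
compound 3, `C=C(c1ccc(OC)c(F)c1)C1COC2(CCCC2)OO1`, 55800 nM

In a functional assay on BEAS-2B cells (Homo sapiens) for inhibition, read by MTT assay, with a stated time of 72 h (on this read-out higher numbers stand for weaker inhibition and lower numbers for stronger inhibition), compound 2 gives 68700 nM and compound 3 gives 55800 nM; these two numbers sit within the scatter of each other. Compound 1 reaches only a limit of this assay, > 100000 nM, and not a number. The change from compound 2 to compound 1 is fluoro in place of methoxy on an aromatic carbon. It made an at least 1.4-fold higher number from compound 2 to compound 1 (0.16 log units; that floor lies within the scatter), a floor that is set by the limit of > 100000 nM in this assay, at which 1 of the 3 values shown sits. How the core of compound 2 differs from the core of compound 3 is not broken down here.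

Compound 4, `C=C(c1ccc(F)c(F)c1)C1COC2(CCCC2)OO1`, has not yet been measured in this assay. Among the measured compounds shown here, it differs from compound 3 by fluoro in place of methoxy on an aromatic carbon, the same change at the same place as the one from compound 2 to compound 1. The step expected in this assay is a 2.0-fold higher number from compound 3 to compound 4 (0.29 log units; within the scatter), and this rests on the measured step of an at least 1.4-fold higher number from compound 2 to compound 1 (0.16 log units; that floor lies within the scatter), with the value of compound 1 being a limit. Compound 4 is therefore estimated at 110000 nM, most likely between 55000 nM and 260000 nM, with a fair chance that this assay again reports only a limit.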

Compound 4, half-maximal inhibitory concentration: 73600 nM
Compound 4: middle estimate off by 1.5-fold (0.17 log units), on the high side, and the stated range covers the measured number.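

Fluoro in place of methoxy made a 1.3-fold higher number from compound 3 to compound 4 (0.12 log units; within the scatter) in this assay, so on the core of compound 3 the change stays within the scatter. Set beside the earlier case, the two steps read as follows: the same change on two cores in this assay, an at least 1.4-fold higher number (0.16 log units; that floor lies within the scatter) from compound 2 to compound 1 and a 1.3-fold higher number (0.12 log units; within the scatter) from compound 3 to compound 4; the limit leaves it open whether they differ. Compound 1 gives > 100000 nM, which is a limit and not a number, so the compounds shown do not establish that the change carries from one core to the other with the same size, nor that it differs between them.

What the compounds shown leave open is whether another group in the same place, such as chloro, a nitrile or an amine, would move the number beyond the scatter on either core. As far as these compounds go, it also remains open how the change would behave on a core that carries a longer chain in place of what the cores of compound 2 and compound 3 hold.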